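The source may hold more compounds than are shown below. What is called first, only, known or untested is meant among the compounds shown, and "the series" means these compounds.

Measured compounds in a functional assay on K562 cells (Homo sapiens) for cytotoxicity, read by WST assay, with a stated time of 72 h; on this read-out higher numbers stand for weaker inhibition and lower numbers for stronger inhibition:
compound 1 `COc1cc2c(Nc3nc4ccc(C(=O)Nc5c(C)cc(C)cc5C)cc4s3)ncnc2cc1OCCCN1CCC(C)CC1`, 5900 nM
compound 2 `CCN(CC)CCCOc1cc2ncnc(Nc3nc4ccc(C(=O)Nc5c(C)cccc5C)cc4s3)c2cc1OC`, 28400 nM
compound 3 `COc1cc2c(Nc3nc4ccc(C(=O)Nc5c(C)cccc5C)cc4s3)ncnc2cc1OCCCN1CCCCC1`, 13700 nM

Compound 1 gives the lowest number of the three in this assay. Its nearest neighbour is compound 3, whose value stands higher, and compound 2 stands higher still. Going by the values given here, the one step in this set that changes a single place runs from compound 2 to compound 3, where a 2.1-fold lower number from compound 2 to compound 3 (0.32 log units; beyond the scatter); the amine at the end of the propoxy chain was exchanged there, piperidin-1-yl in place of diethylamino. Compound 1 and compound 3 differ in more than one place, so only their two values can be compared, and they lie beyond the scatter of each other.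

Compound 4 `COc1cc2c(Nc3nc4ccc(C(=O)Nc5c(C)cc(C)cc5C)cc4s3)ncnc2cc1OCCCN1CCCCC1C` is the unmeasured compound. It differs from compound 1 by 2-methylpiperidin-1-yl in place of 4-methylpiperidin-1-yl on a saturated chain carbon, three bonds along the chain from an oxygen on an aromatic ring; the two have the same atoms, joined differently. Among the compounds with values here, no measured step moves a methyl within a piperidine ring, so the single amine exchange from compound 2 to compound 3 bears on it only loosely, and that step was modest. Compound 4 is therefore expected to sit close to compound 1 in this assay, with a step of a 1.2-fold higher number from compound 1 to compound 4 (0.07 log units; within the scatter) that is estimated to stay within the scatter. The estimate for compound 4 is 7000 nM, with a range from 2500 nM to 20000 nM.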

Compound 4, half-maximal inhibitory concentration: 3500 nM
Beside the measured number, compound 4's estimate is 2.0-fold (0.30 log units) above it; measured number inside the range.
By their numbers in this assay, from the lowest: compounds 4 and 1 (each within the scatter of the next); then compound 3; then compound 2.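

In this assay the exchange of 4-methylpiperidin-1-yl for 2-methylpiperidin-1-yl on the propyl chain gives a 1.7-fold lower number from compound 1 to compound 4 (0.23 log units; within the scatter) and so leaves the two isomers indistinguishable on this read-out. The earlier compounds shown here showed only that exchanging one amine for a different one at this place can register, as in a 2.1-fold lower number from compound 2 to compound 3 (0.32 log units; beyond the scatter) where diethylamino gives way to piperidin-1-yl; this pair adds that, for these two compounds, moving the methyl around the piperidine ring with the same atoms kept produces no difference beyond the scatter. No evidence is available that accounts for either value or for what the ring methyl does at this place.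

The compounds shown leave open how 3-methylpiperidin-1-yl, pyrrolidin-1-yl or morpholin-4-yl would read on the same chain, and whether a 2-(2-methylpiperidin-1-yl)ethyl chain would read like the 3-(2-methylpiperidin-1-yl)propyl chain. They also leave open whether the same shift of the methyl would read alike on the core of compound 3, which carries one methyl fewer on its anilide ring.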